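Cyclohexyl to Isobutyl on an Amine, Measured Once, Expected Twice

The compounds below may be only part of what the source reports. "The series", "measured", "known", "first", "only" and "open" are said of these compounds alone.

Compound 1, `COc1cc(/C=C/C(=O)/C=C(/C=C/c2ccc(OC(C)=O)c(OC)c2)NC2CCCCC2)ccc1OC(C)=O`, was tested in a functional assay on Caco-2 cells (Homo sapiens), read by fluorescence, tested at 1 uM (a higher number here means a weaker effect of the compound at the concentration tested, a lower number a stronger effect), where compound 1 gives 89%. Compound 2, `COc1cc(/C=C/C(=O)/C=C(/C=C/c2ccc(OC(C)=O)c(OC)c2)NCC(C)C)ccc1OC(C)=O`, differs from compound 1 in one place, (isobutyl in place of cyclohexyl on an amine nitrogen). In this assay compound 2 gives 96%. The step is a number 7 percentage points higher from compound 1 to compound 2 (within the scatter), so this change did not move the read-out beyond the usual spread of repeated measurements.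

Compound 3, `COc1cc(/C=C/C(=O)/C=C(/C=C/c2ccc(O)c(OC)c2)NC2CCCCC2)ccc1O`, shares the same kind of skeleton but its core differs from that of compound 1 in more than one place; the difference between the two cores is not broken down here. In this assay compound 3 gives 88%.

Compound 4, `COc1cc(/C=C/C(=O)/C=C(/C=C/c2ccc(O)c(OC)c2)NCC(C)C)ccc1O`, has not yet been measured. It stands to compound 3 exactly as compound 2 stands to compound 1: the change is isobutyl in place of cyclohexyl on an amine nitrogen, and the place is described in the same words for both pairs, on an amine nitrogen whose other neighbours are a double-bonded chain carbon. It is therefore the same change, made on a second core.

Because the measured step of a number 7 percentage points higher from compound 1 to compound 2 (within the scatter) stayed within the scatter, the step of a number 6 percentage points higher from compound 3 to compound 4 (within the scatter) is expected to be of similar size, a small shift at most. For compound 4 the estimated value in this assay is 94%, with the likely range running from 84% to 103%.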

Compound 4, a percentage reported as activity, at one concentration (the size of the read-out at that concentration, not a potency): 91%
For compound 4 the middle estimate is 3 percentage points above the measured one, within the range that was stated.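

On the second core, putting isobutyl in place of cyclohexyl on an amine nitrogen gives, in this assay, a number 3 percentage points higher from compound 3 to compound 4 (within the scatter). Set beside the same change on the first core, the two steps agree as closely as this read-out can tell: the same change on two cores in this assay, a number 7 percentage points higher (within the scatter) from compound 1 to compound 2 and a number 3 percentage points higher (within the scatter) from compound 3 to compound 4, 4 percentage points apart, within the scatter of two such steps. Among these compounds, two steps that both stay within the scatter show only that this exchange left the read-out unmoved on these two cores at a single tested concentration; they do not show that the step has a fixed size or that it would hold on a further core, and a read-out at one concentration is not a potency.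

The compounds shown carry only cyclohexyl or isobutyl on the amine nitrogen, both made of carbon alone, so it remains open whether a group such as a carboxylic acid, a second amine or a much longer chain in that place would move the read-out beyond the scatter. As far as these compounds go, it also remains open whether a step large enough to stand clear of the scatter would carry from one core to the other as this small one appears to do.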